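A few compounds are considered here, and "the series" means these few. Any claim that something is new, unique, unknown or untested is made for them only; others in the source may bear on it.

Compound 1 `OC[C@H]1O[C@@H](n2cnc3c(NCc4ccc(F)cc4F)ncnc32)[C@H](O)[C@@H]1O` — in a functional assay on MCF cells (Homo sapiens) for antiproliferative activity, with a stated time of 72 h (on this read-out higher numbers stand for weaker inhibition and lower numbers for stronger inhibition), compound 1 gives > 166000 nM, a limit of the assay rather than a number.
Compound 2 `COc1cccc(CNc2ncnc3c2ncn3[C@@H]2O[C@H](CO)[C@@H](O)[C@H]2O)c1O` — compound 2 gives 20200 nM.
Compound 3 `OC[C@H]1O[C@@H](n2cnc3c(NCc4cccc(O)c4O)ncnc32)[C@H](O)[C@@H]1O` — compound 3 gives 5200 nM.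

Compound 3 holds the lowest of the two numbers shown; its nearest neighbour is compound 2, and the step of a 3.9-fold lower number from compound 2 to compound 3 (0.59 log units; beyond the scatter) lies beyond the scatter. Compound 1 sits at the limit (the limit of > 166000 nM in this assay, at which 1 of the 3 values shown sits), so both steps away from it, an at least 8.2-fold lower number from compound 1 to compound 2 (0.91 log units; beyond the scatter) and an at least 31-fold lower number from compound 1 to compound 3 (1.50 log units; beyond the scatter), are at least as large as stated. Compound 4 `OC[C@H]1O[C@@H](n2cnc3c(NCc4ccc(C(F)(F)F)cc4)ncnc32)[C@H](O)[C@@H]1O` has not been measured. Its change from compound 3 is 4-(trifluoromethyl)phenyl in place of 2,3-dihydroxyphenyl on a saturated chain carbon bound to a nitrogen on an aromatic ring. The group that leaves carries the two hydroxyls that separate compound 3 from the weak compound 1, and the group that enters, like the 2,4-difluorophenyl of compound 1, carries no hydrogen-bond donor or acceptor. The step of an at least 31-fold lower number from compound 1 to compound 3 (1.50 log units; beyond the scatter) therefore bears on this change in reverse, and a large rise in number is expected for compound 4, with a fair chance that the assay again reports only a limit. The expected step is a 29-fold higher number from compound 3 to compound 4 (1.46 log units; beyond the scatter), and compound 4 is estimated at 150000 nM, in the range 30000 nM to 600000 nM.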

Compound 4, half-maximal inhibitory concentration: > 166000 nM
Compound 4 ended at the assay's limit; the forecaster's own chance of this, stated with the estimate: 55%; middle value at least 1.1-fold (0.04 log units) away from the limit.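

In this assay, the step of an at least 31-fold higher number from compound 3 to compound 4 (1.50 log units; beyond the scatter) and the step of an at least 8.2-fold higher number from compound 2 to compound 4 (0.91 log units; beyond the scatter) show that a second phenyl group without hydroxyls, on a saturated chain carbon bound to a nitrogen on an aromatic ring, also loses the measurable inhibition seen with compound 2 and compound 3. The weak read-out of compound 1 is therefore not peculiar to 2,4-difluorophenyl, and across these compounds, none of which goes against the pattern, both groups with an oxygen on the ring give a number and both groups with only fluorine-bearing substituents do not. The step from compound 1 to compound 4 cannot be read, and the two fluorinated groups cannot be ranked, since both compounds end at the same limit of the assay: the limit of > 166000 nM in this assay, at which 2 of the 4 values shown sit.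

The compounds shown leave open whether a single hydroxyl on the phenyl ring would suffice, and whether the link to lower numbers belongs to the hydroxyl itself. An amine or a carboxylic acid in its place, or a plain unsubstituted phenyl, would test how far that link extends.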